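Swapping a pyridine for a dimethoxyphenyl ring

This account rests on a few compounds, and the source may have more. Where it says the series, first, only, none or still open, it means among the compounds named here.

Measured so far in an ADME assay on Raji cells (Homo sapiens) for cytotoxicity, read by CellTiter-Glo and resazurin assay, with a stated time of 72 h; on this read-out higher numbers stand for an effect only at larger amounts of compound and lower numbers for an effect already at smaller amounts:
- compound 1 `CC(C)N(Cc1cccc(OCCCCCC(=O)O)c1)C(=O)c1ccc(-c2ccc(Cl)c(Cl)c2)cc1` gives only a limit, > 26000 nM.
- compound 2 `CCOC(=O)CCCCCOc1cccc(CN(C(=O)c2ccc(-c3cccnc3)cc2)C(C)C)c1` gives only a limit, > 26000 nM.

Going by the values given here, compound 2 stands at the limit of > 26000 nM in this assay, at which 2 of the 2 values shown sit; no actual number is known for it, and the same holds for the only other value. Compound 3 `CCOC(=O)CCCCCOc1cccc(CN(C(=O)c2ccc(-c3cc(OC)cc(OC)c3)cc2)C(C)C)c1` differs from compound 2 by 3,5-dimethoxyphenyl in place of pyridin-3-yl on an aromatic carbon. Among the compounds with values here, no step between measured compounds is known, so the size of this change in this assay is open; the expectation is no shift beyond the scatter. Compound 3 is expected to give 40000 nM, between 15000 nM and 120000 nM, most likely again as a limit only. The expected step is a step that the limit leaves unreadable from compound 2 to compound 3.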

Compound 3, half-maximal effective concentration: > 26000 nM
Compound 3: only a limit was reported (the forecaster's own chance of this, stated with the estimate: 80%); the middle value does not contradict the limit.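

Compound 2 and compound 3 both give only a limit in this assay, and no step can be read between them. The compounds shown leave open what actual value any of them has: the limit of > 26000 nM in this assay, at which 3 of the 3 values shown sit.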